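Sulfonyl chain notes: propyl to cyclopropyl

The compounds below may be only part of what the source reports. "The series", "measured", "known", "first", "only" and "open" are said of these compounds alone.

Values in a functional assay on DU-145 cells (Homo sapiens) for antiproliferative activity, read by MTT assay, with a stated time of 3 days; on this read-out higher numbers stand for weaker inhibition and lower numbers for stronger inhibition:
- compound 1 `CCS(=O)(=O)Nc1ccc(-c2cc(=O)c3c(O)cc(OC)c(OC(C)C)c3o2)cc1`: 17000 nM
- compound 2 `CCCS(=O)(=O)Nc1ccc(-c2cc(=O)c3c(O)cc(OC)c(OC(C)C)c3o2)cc1`: 76900 nM

Of the two measured compounds, compound 2 has the higher number, 76900 nM, and so the weaker inhibition. The next compound for comparison is compound 3 `COc1cc(O)c2c(=O)cc(-c3ccc(NS(=O)(=O)C4CC4)cc3)oc2c1OC(C)C`, which is not yet measured. The structural change is cyclopropyl in place of propyl on a sulfonyl sulfur.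

Among the compounds with values here, only one measured step bears on this change: a 4.5-fold higher number from compound 1 to compound 2 (0.66 log units; beyond the scatter). It is a modest step beyond the scatter, with a methyl in place of hydrogen on a saturated chain carbon, two bonds along the chain from a sulfonyl sulfur. Within the data shown here, no measured compound carries a ring at this place, so this chain step is only a loose guide. Among the measured compounds shown here, on the evidence of that step, a modest move towards a lower number is expected, of a size no greater than the step from compound 1, and a result within the scatter remains possible.

The expected change is a 2.6-fold lower number from compound 2 to compound 3 (0.41 log units; beyond the scatter). For compound 3 the estimated value is 30000 nM, with an expected range of 10000 nM to 90000 nM.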

Compound 3, half-maximal inhibitory concentration: 48700 nM
Compound 3: the middle estimate sits 1.6-fold (0.21 log units) below what was measured; measured number inside the range.
By their numbers in this assay, from the lowest: compound 1; then compounds 3 and 2 (each within the scatter of the next).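

Within the data shown here, compound 3 is the first compound here to carry a ring on the sulfonyl sulfur, and in this assay closing the three carbons into cyclopropyl does not separate it from the open propyl chain (a 1.6-fold lower number from compound 2 to compound 3 (0.20 log units; within the scatter)). The ring also leaves compound 3 apart from the ethyl compound (a 2.9-fold higher number from compound 1 to compound 3 (0.46 log units; beyond the scatter)), so compound 1 stays the most potent of the three, and both groups with three carbons sit on the weaker side of ethyl, whether open or closed. No measurement shown gives a reason for these numbers.

The compounds shown leave open how methyl, a longer chain such as butyl, or a larger ring such as cyclobutyl on the sulfonyl sulfur would read in this assay, and so whether ethyl marks a real optimum or only the best of three neighbouring groups. An amine or a carboxylic acid at the end of the sulfonyl chain is also untested ground in this set, as is any reading of these sulfonyl changes on a core other than the shared one.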